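Nitro-to-Amino Change Carried onto a Second Core

The source may report more compounds than this note shows. Statements on the series, on what has been measured and on what is new or still open speak of the compounds shown alone.

Compound 1 `Cc1ccc(NC(=O)c2cccc(C(F)(F)F)c2)cc1NC(=O)c1cnc(Nc2ccc(C)c([N+](=O)[O-])c2)nc1N(C)C` is the nitro member of the first pair, and in a functional assay on K562 cells (Homo sapiens) for antiproliferative activity, read by CellTiter-Glo and CCK-8 assay, with a stated time of 72 h (a higher number here means a weaker inhibitor of growth, a lower number a stronger inhibitor of growth), compound 1 gives > 10000 nM, which is a limit of the assay rather than a number. Compound 2 `Cc1ccc(Nc2ncc(C(=O)Nc3cc(NC(=O)c4cccc(C(F)(F)F)c4)ccc3C)c(N(C)C)n2)cc1N` differs from it by amino in place of nitro on an aromatic carbon. In this assay compound 2 gives 1210 nM. The step of an at least 8.2-fold lower number from compound 1 to compound 2 (0.91 log units; beyond the scatter) can be stated only as a lower bound because of the limit of > 10000 nM in this assay, at which 2 of the 3 values shown sit. Compound 3 `CNc1nc(Nc2ccc(C)c([N+](=O)[O-])c2)ncc1C(=O)Nc1cc(NC(=O)c2ccccc2OC)ccc1C` rests on a different core; how that core differs from the core of compound 1 is not broken down here. In this assay compound 3 gives > 10000 nM, again a limit of the assay. Among the measured compounds shown here, compound 4 `CNc1nc(Nc2ccc(C)c(N)c2)ncc1C(=O)Nc1cc(NC(=O)c2ccccc2OC)ccc1C` differs from compound 3 by amino in place of nitro on an aromatic carbon, the same change, made at the same place, as the one leading from compound 1 to compound 2. A step of similar size is expected here, an at least 3.3-fold lower number from compound 3 to compound 4 (0.52 log units; beyond the scatter), which rests on the measured step of an at least 8.2-fold lower number from compound 1 to compound 2 (0.91 log units; beyond the scatter) being at least modest. Compound 4 is therefore expected to give about 3000 nM in this assay, with a likely range from 800 nM to 12000 nM.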

Compound 4, concentration for 50% growth inhibition: 1980 nM
Beside the measured number, compound 4's estimate is 1.5-fold (0.18 log units) above it; the range from low to high includes it.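

In this assay, amino in place of nitro on the second core again lowers the number, giving an at least 5.0-fold lower number from compound 3 to compound 4 (0.70 log units; beyond the scatter). The change therefore moves in the same direction on the core of compound 1 and on the core of compound 3, and in both pairs the amino member gives a measured value where the nitro member stands at a limit of the assay. This does not show that the step has the same size on the two cores, since both steps are known only as lower bounds: the same change on two cores in this assay, an at least 8.2-fold lower number (0.91 log units; beyond the scatter) from compound 1 to compound 2 and an at least 5.0-fold lower number (0.70 log units; beyond the scatter) from compound 3 to compound 4; the limit leaves it open whether they differ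

The compounds shown leave open whether another group at this place on the ring, such as a hydroxyl group, a methylamino group or an acetamide, would give a lower number than amino does. Among the compounds shown here, they also leave open how far the step depends on the other parts of the molecule, as the two pairs share only this one change and no pair here separates those parts.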